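The source may report more compounds than this note shows. Statements on the series, on what has been measured and on what is new or still open speak of the compounds shown alone.

Measured compounds:
compound 1 `Nc1ccccc1NC(=O)c1ccc(CSC(=S)N2CCN(C(c3ccccc3)c3ccccc3)CC2)cc1` — 9.9%;
compound 2 `Nc1ccccc1NC(=O)c1ccc(CSC(=S)N2CCc3ccccc32)cc1` — 87%;
compound 3 `Nc1ccccc1NC(=O)c1ccc(CSC(=S)N2CCN(c3ccncc3)CC2)cc1` — 87.1%.

In a functional assay on MGC-803 cells (Homo sapiens) for antiproliferative activity, read by CCK-8 assay, with a stated time of 72 h, tested at 8 uM (a lower number here means a weaker effect, a higher number a stronger effect of the compound at the concentration tested), compound 2 gives 87%, the second highest of the three numbers. Its nearest neighbour is compound 3, whose value sits within the scatter of it, so no order between the two can be stated; compound 1 lies far below both, beyond the scatter. Compound 4 `Nc1ccccc1NC(=O)c1ccc(CSC(=S)N2CCCC2)cc1` has not yet been measured. It differs from compound 2 in one place: pyrrolidin-1-yl in place of 2,3-dihydro-1H-indol-1-yl on a thiocarbonyl carbon. Within the data shown here, no measured pair shows this change, so its size cannot be read from the data. The expected step is estimated as a number 27 percentage points lower from compound 2 to compound 4 (beyond the scatter) and should be a downward one of moderate size. For compound 4 an inhibition of 60% is estimated, ranging from 25% to 88%.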

Compound 4, a percentage reported as inhibition, at one concentration (the size of the read-out at that concentration, not a potency): 83.4%
For compound 4 the middle estimate is 23.4 percentage points below the measured one; the range from low to high includes it.
By their numbers in this assay, from the lowest: compound 1; then compounds 4, 2 and 3 (each within the scatter of the next).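

In this assay, the step at this thiocarbonyl carbon reads a number 3.6 percentage points lower from compound 2 to compound 4 (within the scatter). Pyrrolidin-1-yl carries no six-membered aromatic ring, so that ring of 2,3-dihydro-1H-indol-1-yl is not required for a read-out of this size at the concentration tested. No available evidence bears on this result. Still open, as far as these compounds go, is whether an open-chain diethylamino group or a morpholin-4-yl ring on the same carbon would fit this picture. Among these compounds, the single step also leaves open whether the same holds at lower concentrations.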